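Urea-side swap: difluoropiperidine for dimethylaminopropyl

This account rests on a few compounds, and the source may have more. Where it says the series, first, only, none or still open, it means among the compounds named here.

Compound 3 `CN(C)CCCN(C)C(=O)Nc1cc2c(Nc3ccc(F)c(Cl)c3)ncnc2cc1O[C@H]1CCOC1` holds the lowest number of the three in a functional assay on A-431 cells (Homo sapiens) for antiproliferative activity, read by sulforhodamine B assay, with a stated time of 72 h (a lower number here means a stronger inhibitor, a higher number a weaker inhibitor), at 200 nM; compound 1 `COCCCNC(=O)Nc1cc2c(Nc3ccc(F)c(Cl)c3)ncnc2cc1O[C@H]1CCOC1` gives 4100 nM and compound 2 `COC(CCNC(=O)Nc1cc2c(Nc3ccc(F)c(Cl)c3)ncnc2cc1O[C@H]1CCOC1)OC` gives 22000 nM. Compound 4 `O=C(Nc1cc2c(Nc3ccc(F)c(Cl)c3)ncnc2cc1O[C@H]1CCOC1)N1CCC(F)(F)CC1` differs from compound 3 by 4,4-difluoropiperidin-1-yl in place of (3-(dimethylamino)propyl)(methyl)amino on a carbonyl carbon. For the measured compounds named here, the measured steps that bear on this are a 21-fold lower number from compound 1 to compound 3 (1.31 log units; beyond the scatter) and a 110-fold lower number from compound 2 to compound 3 (2.04 log units; beyond the scatter), both of which brought in the (3-(dimethylamino)propyl)(methyl)amino group that compound 4 now gives up; no measured step reaches a ring of this kind, so the size of the reverse move is uncertain. Compound 4 is therefore expected to lose ground, estimated at 3000 nM with a range of 800 nM to 12000 nM, an expected step of a 15-fold higher number from compound 3 to compound 4 (1.18 log units; beyond the scatter) in this assay.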

Compound 4, half-maximal inhibitory concentration: 1860 nM
For compound 4 the middle estimate is 1.6-fold (0.21 log units) above the measured one; the range from low to high includes it.
By their numbers in this assay, from the lowest: compound 3; then compound 4; then compound 1; then compound 2.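

On the carbonyl carbon, 4,4-difluoropiperidin-1-yl outperforms both open chains in this assay, with a 2.2-fold lower number from compound 1 to compound 4 (0.34 log units; beyond the scatter) against (3-methoxypropyl)amino and a 12-fold lower number from compound 2 to compound 4 (1.07 log units; beyond the scatter) against (3,3-dimethoxypropyl)amino. Yet a 9.3-fold higher number from compound 3 to compound 4 (0.97 log units; beyond the scatter) shows that this ring does not match (3-(dimethylamino)propyl)(methyl)amino at this position. No evidence on hand accounts for this order. Still open, on these data alone, is whether an unfluorinated piperidine, a morpholine or a 4-methylpiperazine on the same carbonyl carbon would stand nearer compound 3 or compound 4.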